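A few compounds are considered here, and "the series" means these few. Any claim that something is new, unique, unknown or untested is made for them only; others in the source may bear on it.

Measured so far in a physicochemical assay, read by spectrophotometry, with a stated time of 60 min, tested at 35 uM; on this read-out lower numbers stand for a weaker effect and higher numbers for a stronger effect at the one concentration tested:

Compound 1 `COc1ccc(/C=C/C=N/NC(=O)c2ccc(C(C)(C)C)cc2)cc1` gives 6.6%.
Compound 2 `COc1ccc(/C=C/C=N/NC(=O)c2ccc(O)cc2)cc1` gives 3.4%.
Compound 3 `CC(C)(C)c1ccc(C(=O)N/N=C/c2cc(O)cc(O)c2)cc1` gives 7%.

Compound 1 and compound 2 share a core and differ by hydroxy in place of tert-butyl on an aromatic carbon; this change made a step of a number 3.2 percentage points lower from compound 1 to compound 2 (within the scatter). Compound 3 stands on a different core; the difference between the two cores is not broken down here, and its value and those of compound 1 and compound 2 all lie within the scatter of one another, so no order among the three is claimed.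

Compound 4 `O=C(N/N=C/c1cc(O)cc(O)c1)c1ccc(O)cc1` is not yet measured. It differs from compound 3 by hydroxy in place of tert-butyl on an aromatic carbon, the same change as that from compound 1 to compound 2, in the same place. Because the earlier step was a number 3.2 percentage points lower from compound 1 to compound 2 (within the scatter), the expected step is of similar size, a number 3 percentage points lower from compound 3 to compound 4 (within the scatter), resting on one pair only. For compound 4 the estimate in this assay is 4%, expected between 0% and 10%.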

Compound 4, a percentage reported as inhibition, at one concentration (the size of the read-out at that concentration, not a potency): 5.6%
The estimate for compound 4 lay 1.6 percentage points below the measured number; the range from low to high includes it.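

In this assay, hydroxy in place of tert-butyl gives a number 1.4 percentage points lower from compound 3 to compound 4 (within the scatter), against a number 3.2 percentage points lower from compound 1 to compound 2 (within the scatter) on the other core. Both steps lie within the scatter, so the two cores agree only in showing no readable effect of this change at the one concentration tested; a transferable effect of the change is not shown, and two steps this small cannot establish one. Nothing at hand bears on a cause for this result.

Open, on these data alone, is whether an amine, a carboxylic acid or a longer chain at this aromatic carbon would give a step beyond the scatter. Also open, as far as these compounds go, is whether the change would behave alike on a third core.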